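The compounds below may be only part of what the source reports. "The series", "measured", "known", "first", "only" and "open" are said of these compounds alone.

Measured so far:
- compound 1, `COc1cc(C(=O)N/N=C/c2ccc(F)c(F)c2)cc(OC)c1OC`: 43.7%
- compound 2, `COc1cc(C2=NN(C(C)=O)C(c3cc(Cl)cc(Cl)c3)O2)cc(OC)c1OC`: 93.9%
- compound 3, `COc1cc(C(=O)N/N=C/c2ccccc2C(F)(F)F)cc(OC)c1OC`: 52.9%

In a functional assay on PC-3 cells (Homo sapiens) for antiproliferative activity, read by MTT assay, tested at 5 uM (a lower number here means a weaker effect, a higher number a stronger effect of the compound at the concentration tested), compound 2 stands highest of the three numbers. Its nearest neighbour is compound 3, whose value lies lower by a margin beyond the scatter; compound 1 lies lower still, also beyond the scatter. Among the measured compounds shown here, compound 2 is thus the most active of the three measured here, and it is the only one with the core carrying the acetyl group, the other two sharing an acylhydrazone-type linkage instead.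

Compound 4, `COc1cc(C2=NN(C(C)=O)C(c3ccc(Cl)c(Cl)c3)O2)cc(OC)c1OC`, is the next structure to be measured. It differs from compound 2 only in one place: 3,4-dichlorophenyl in place of 3,5-dichlorophenyl on a saturated ring carbon. For the measured compounds named here, no step between two measured compounds isolates such a rearrangement of the two chlorines, so the size of the effect cannot be read from the numbers at hand. The same atoms, the same ring and the same place argue for a small step, if any, and the estimate is placed slightly below compound 2 to allow for the usual variability at a high inhibition value.

Compound 4 is expected to give 85%, with a range from 65% to 98%. The step from compound 2 to compound 4 is thus expected to be a number 8.9 percentage points lower from compound 2 to compound 4 (within the scatter), not beyond the scatter.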

Compound 4, a percentage reported as inhibition, at one concentration (the size of the read-out at that concentration, not a potency): 26.1%
Estimate against measurement, compound 4: 58.9 percentage points above; the measured number lies below the stated range.
By their numbers in this assay, from the lowest: compound 4; then compounds 1 and 3 (each within the scatter of the next); then compound 2.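

In this assay, 3,4-dichlorophenyl in place of 3,5-dichlorophenyl on the saturated ring carbon gives a number 67.8 percentage points lower from compound 2 to compound 4 (beyond the scatter), the first step read at this position. The two groups have the same atoms and the same counts, so the arrangement of the two chlorines alone separates compound 2 from compound 4, and this position is far from indifferent to that arrangement. Nothing available here bears on the reason for this step.

Still open, from the compounds shown here alone, is how an unsubstituted phenyl or an aminophenyl on the same carbon would read in this assay, which would show whether chlorine is needed there at all. Also open, going by these compounds, is whether the large step persists when a longer acyl chain, such as propanoyl, replaces the acetyl group.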